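The source may hold more compounds than are shown below. What is called first, only, known or untested is meant among the compounds shown, and "the series" means these compounds.

Compound 1 `COCCCN1CCc2c(sc(NC(=O)Nc3ccc(Cl)cc3)c2C(N)=O)C1` is a urea on a shared core whose ring amine carries a 2-methoxyethyl chain. In a functional assay (strain AB) with Danio rerio as the target, read by microscopy, with a stated time of 1 h (on this read-out lower numbers stand for an effect already at smaller amounts and higher numbers for an effect only at larger amounts of compound), compound 1 gives 2400 nM, the highest of the two numbers shown here. Within the data shown here, compound 2 `NC(=O)c1c(NC(=O)Nc2ccc(Cl)cc2)sc2c1CCN(CCCNC(=O)CCc1cccnc1)C2` gives 470 nM, and the step of a 5.1-fold lower number from compound 1 to compound 2 (0.71 log units; beyond the scatter) is the only measured change on that chain. Compound 3 `CCN1CCc2c(sc(NC(=O)NCC3CCCO3)c2C(N)=O)C1` carries a different urea partner and an ethyl group on the ring amine; for compound 3 the assay reports only a limit, > 25000 nM, and the limit of > 25000 nM in this assay, at which 1 of the 3 values shown sits, marks where that limit sits.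

Compound 4 `NC(=O)c1c(NC(=O)Nc2ccc(Cl)cc2)sc2c1CCN(CC1CCCC1)C2` differs from compound 1 in one place: cyclopentyl in place of 2-methoxyethyl on a saturated chain carbon bound to an amine nitrogen in a ring. Among the measured compounds shown here, the one measured step touching this chain, a 5.1-fold lower number from compound 1 to compound 2 (0.71 log units; beyond the scatter), placed a longer group three bonds along the chain from an amine nitrogen in a ring rather than exchanging the chain itself for a ring, so it speaks only loosely to the new change. The ring amine and the urea are untouched. A step of no more than modest size in either direction is therefore expected, with a 1.2-fold lower number from compound 1 to compound 4 (0.08 log units; within the scatter) as the estimated outcome for compound 4. Compound 4 is expected to give 2000 nM, between 700 nM and 6000 nM.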

Compound 4, half-maximal effective concentration: 1830 nM
Beside the measured number, compound 4's estimate is 1.1-fold (0.04 log units) above it; measured number inside the range.
By their numbers in this assay, from the lowest: compound 2; then compounds 4 and 1 (each within the scatter of the next). At a limit, above all of these: compound 3.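

In this assay the exchange of 2-methoxyethyl for cyclopentyl gives a 1.3-fold lower number from compound 1 to compound 4 (0.12 log units; within the scatter), so the two compounds cannot be told apart on this read-out. Among these compounds, on a saturated chain carbon bound to an amine nitrogen in a ring, an open chain with one hydrogen-bond acceptor can thus give way to a five-membered carbon ring with no acceptor and no step beyond the scatter, whereas the earlier step on this chain, a 5.1-fold lower number from compound 1 to compound 2 (0.71 log units; beyond the scatter), showed only that a much longer group carrying an amide and a pyridine ring goes with a lower number. Nothing measured among these compounds bears on why the number holds steady across this exchange.

The compounds shown leave open whether an amine or a carboxylic acid on this chain, or a larger carbon ring such as cyclohexyl, would move the number beyond the scatter. Among the compounds shown here, with compound 2 as the only compound standing beyond the scatter from compound 1, it also stays open which part of its longer chain, the amide or the pyridine ring, goes with its lower number.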